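The source may report more compounds than this note shows. Statements on the series, on what has been measured and on what is new or still open speak of the compounds shown alone.

Three compounds share one core, an amide of a piperidine carrying a tert-butyl-isoxazole, and differ only in the group on the ring nitrogen. Compound 1 `CC(C)(C)c1cc(NC(=O)[C@@H]2CCCCN2Cc2ccc(Cl)cc2)no1` carries a 4-chlorobenzyl there, compound 2 `CC(C)(C)c1cc(NC(=O)[C@@H]2CCCCN2C(=O)c2ccccc2)no1` a benzoyl, and compound 3 `CC(C)(C)c1cc(NC(=O)[C@@H]2CCCCN2C(=O)N2CCOCC2)no1` a (morpholin-4-yl)carbonyl. In an ADME assay (liver) for metabolic stability, with Liver microsome (Homo sapiens) as the target, read by LC-MS, using microsomes and NADPH, tested at 1 uM (on this read-out lower numbers stand for a shorter-lived compound and higher numbers for a longer-lived compound), compound 1 gives 0.15 h. In this assay compound 2 gives 0.683 h. For compound 3 this assay reports only a limit, > 2 h, not a number. The change from benzyl to benzoyl brings a 4.6-fold higher number from compound 1 to compound 2 (0.66 log units; beyond the scatter), the change to the morpholinyl carbonyl brings an at least 13-fold higher number from compound 1 to compound 3 (1.12 log units; beyond the scatter), and between the two carbonyl compounds there is an at least 2.9-fold higher number from compound 2 to compound 3 (0.46 log units; beyond the scatter). Compound 3 thus stands at the upper edge of what is shown, where (the limit of > 2 h in this assay, at which 1 of the 3 values shown sits).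

Compound 4 `CC(C)(C)c1cc(NC(=O)[C@@H]2CCCCN2C(=O)N2CC[S+]([O-])CC2)no1` differs from compound 3 only in that (a group of 7 heavy atoms (4 carbon, 1 nitrogen, 1 oxygen, 1 sulfur; one six-membered non-aromatic ring with 2 hetero atoms) in place of a group of 6 heavy atoms (4 carbon, 1 nitrogen, 1 oxygen; one six-membered non-aromatic ring with 2 hetero atoms), on a carbonyl carbon). Both groups are six-membered saturated rings with two hetero atoms attached through the same carbonyl. Among the measured compounds shown here, no measured step tests this kind of swap; the steps seen all concern the group on the ring nitrogen or the exchange of an aromatic ring for a saturated one. With compound 3 already at the limit, no step beyond the scatter is expected, a step that the limit leaves unreadable from compound 3 to compound 4. Compound 4 is estimated at 2.5 h, in the range 1.2 h to 5 h.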

Compound 4, half-life: > 2 h
Compound 4 gave a limit, no number; the forecaster's own chance of this, stated with the estimate: 60%; the middle value is on the limit's open side.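

In this assay compound 4 gives only a limit, as compound 3 does, so the step between them cannot be read, and the swap on the carbonyl carbon can only be said to leave both compounds at the same limit: the limit of > 2 h in this assay, at which 2 of the 4 values shown sit.

Against the earlier compounds, the new sulfur-containing ring on the carbonyl carbon, in place of phenyl, gives an at least 2.9-fold higher number from compound 2 to compound 4 (0.46 log units; beyond the scatter), and the same ring with its carbonyl, in place of 4-chlorobenzyl on the amine nitrogen in a ring, gives an at least 13-fold higher number from compound 1 to compound 4 (1.12 log units; beyond the scatter). Morpholin-4-yl is therefore not the only six-membered non-aromatic ring with 2 hetero atoms on this carbonyl carbon that reaches the limit, since a ring holding sulfur reaches it too.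

On these data alone, how far past the limit compound 3 and compound 4 lie remains unknown, so which of the two lasts longer cannot be said. Also open, as far as these compounds go, is whether a piperidin-1-yl ring, with no second hetero atom, or an open-chain dimethylamino group on the same carbonyl carbon would reach the limit as well.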